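A few compounds are considered here, and "the series" means these few. Any claim that something is new, unique, unknown or untested is made for them only; others in the source may bear on it.

In an ADME assay on S9 fraction from liver (Rattus norvegicus) for metabolic stability, read by LC-MS, using NADPH, with a stated time of 30 min (on this read-out higher numbers stand for a more stable compound and lower numbers for a less stable compound), compound 2 `CCCCCCCCc1ccc(OCC(=O)Cn2nnc(-c3ccc(Cl)cc3)n2)cc1` gives 74%, the highest of the two numbers that exist here, with compound 3 `CCCCCCCCc1ccc(OCC(=O)Cn2nnc(-c3ccccn3)n2)cc1` nearest at 30%. Compound 1 `CCCCCCCCc1ccc(OCC(=O)Cn2nnc(C)n2)cc1` gives only < 5%, which is a limit of the assay rather than a number, as shown by the limit of < 5% in this assay, at which 1 of the 3 values shown sits. Replacing the methyl on the shared core by an aromatic group raised the number in both measured cases: a number at least 69 percentage points higher from compound 1 to compound 2 (beyond the scatter) and a number at least 25 percentage points higher from compound 1 to compound 3 (beyond the scatter). Swapping one aromatic group for another also mattered, since a number 44 percentage points lower from compound 2 to compound 3 (beyond the scatter) was a large drop.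

Compound 4 `CCCCCCCCc1ccc(OCC(=O)Cn2nnc(-c3cccc(C(=O)O)c3)n2)cc1` differs from compound 2 by 3-carboxyphenyl in place of 4-chlorophenyl on an aromatic carbon. Among the measured compounds shown here, the one measured swap between two aromatic groups at this position, a number 44 percentage points lower from compound 2 to compound 3 (beyond the scatter), gave a large fall, and compound 2 already sits at the top of the values seen, so a fall in this assay is the more likely direction for compound 4, although its size cannot be read from a single comparison. Compound 4 is therefore expected to give about 40%, with a plausible range from 15% to 70%. This estimate amounts to an expected step of a number 34 percentage points lower from compound 2 to compound 4 (beyond the scatter).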

Compound 4, percent of the compound remaining: < 5%
Compound 4: only a limit was reported; the forecaster's own chance of this, stated with the estimate: 10%; middle value at least 35 percentage points from the limit.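

The earlier compounds shown here left room to think that any aromatic group at this position lifts the number, but 3-carboxyphenyl goes against that, with a number at least 69 percentage points lower from compound 2 to compound 4 (beyond the scatter) and a number at least 25 percentage points lower from compound 3 to compound 4 (beyond the scatter) in this assay. The 4-chlorophenyl and 3-carboxyphenyl groups both carry one six-membered aromatic ring of carbon only, which shows that having such a ring here does not settle the result and that what the ring carries can make a large difference. Compound 4 gives a limit of the assay rather than a number, and compound 1 also gives a limit, which leaves the step between them unreadable and any other difference in their stability hidden: the limit of < 5% in this assay, at which 2 of the 4 values shown sit.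

The compounds shown leave open whether the fall follows the carboxylic acid itself or its place on the ring, as compound 2 and compound 4 differ in both the group on the ring and its numbered place. A 3-chlorophenyl group, a 4-carboxyphenyl group or a methyl ester of the acid would help to pull these apart.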